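Bulky alkyl variation on the cyanoguanidine series

The compounds below may be only part of what the source reports. "The series", "measured", "known", "first", "only" and "open" are said of these compounds alone.

Measured so far:
compound 1 `CC(C)/N=C(\NC#N)Nc1cccnc1` – 2.5 mg/kg
compound 2 `CC(C)C(C)(C)/N=C(\NC#N)Nc1cccnc1` – 1 mg/kg

In a functional assay on the whole organism (blood, strain Wistar-Okamoto) with Rattus norvegicus as the target, with a stated time of 5 days (on this read-out lower numbers stand for an effect already at smaller amounts and higher numbers for an effect only at larger amounts of compound), compound 2 holds the lowest of the two numbers shown, with compound 1 at a 2.5-fold lower number from compound 1 to compound 2 (0.40 log units; beyond the scatter). Compound 3 `CC(C)CC(C)(C)/N=C(\NC#N)Nc1cccnc1` is not yet measured; it differs from compound 2 by isobutyl in place of isopropyl on a saturated chain carbon bound to a double-bonded nitrogen and two saturated chain carbons. Going by the values given here, the one step that bears on it is the change at the same place, a 2.5-fold lower number from compound 1 to compound 2 (0.40 log units; beyond the scatter), which lengthened the chain there and lowered the number modestly. Compound 3 adds one further carbon at that place, so for compound 3 a step of no change at the digits printed from compound 2 to compound 3 (within the scatter) is expected, most likely within the scatter. Compound 3 is estimated at 1 mg/kg, with a range from 0.4 mg/kg to 2.5 mg/kg.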

Compound 3, minimum effective dose: 2.5 mg/kg
Beside the measured number, compound 3's estimate is 2.5-fold (0.40 log units) below it, and the stated range covers the measured number.
By their numbers in this assay, from the lowest: compound 2; then compounds 1 and 3 (each within the scatter of the next).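

In this assay, the gain from isopropyl at this place does not extend to isobutyl, which gives a 2.5-fold higher number from compound 2 to compound 3 (0.40 log units; beyond the scatter). Set against hydrogen, isobutyl gives no change at the digits printed from compound 1 to compound 3 (within the scatter), so across these compounds the number does not follow the heavy-atom count of the group, and compound 3 goes against any such trend. No evidence is available to explain this turn.

Open, on these data alone, is whether a cyclohexyl group or a longer chain at this place would read like isopropyl or like isobutyl. The compounds shown also leave open whether a shorter group such as ethyl would keep the lower number.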